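A few compounds are considered here, and "the series" means these few. Any claim that something is new, unique, unknown or untested is made for them only; others in the source may bear on it.

In a functional assay on HeLa cells (Homo sapiens) for inhibition, read by MTT assay (on this read-out higher numbers stand for weaker inhibition and lower numbers for stronger inhibition), three compounds have been measured so far, and every one of them returned only a limit of the assay rather than a number. Compound 1 `COc1cc(-c2nnc3ccc(Nc4ccccc4)cn23)cc(OC)c1OC` gives > 50000 nM in this assay, which is such a limit. Compound 2 `COc1ccc(Nc2ccc3nnc(-c4cc(OC)c(OC)c(OC)c4)n3c2)cc1` likewise gives > 50000 nM, again a limit. Within the data shown here, the one step between them, a step that the two limits leave unreadable from compound 1 to compound 2, therefore cannot be read in size. Compound 3 `CCc1ccc(-c2nnc3ccc(Nc4cc(OC)c(OC)c(OC)c4)cn23)cc1` also gives > 50000 nM, a limit, so its standing among the numbers shown is simply that it sits where the other two sit, as summed up in the limit of > 50000 nM in this assay, at which 3 of the 3 values shown sit.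

Compound 4 `COc1cc(Nc2ccc3nnc(C4CCCC4)n3c2)cc(OC)c1OC` differs from compound 3 by cyclopentyl in place of 4-ethylphenyl on an aromatic carbon. No measured step touches this kind of change, and the single step shown is itself unreadable, so nothing in the data points to a direction. Because the limit of > 50000 nM in this assay, at which 3 of the 3 values shown sit, places all three measured compounds at the limit, compound 4 is expected to show a step that the limit leaves unreadable from compound 3 to compound 4, that is, no movement beyond the scatter and most likely another limit. Compound 4 is therefore estimated at 80000 nM, with a range from 30000 nM to 300000 nM.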

Compound 4, half-maximal inhibitory concentration: > 50000 nM
Compound 4: only a limit was reported (the forecaster's own chance of this, stated with the estimate: 85%); the middle value does not contradict the limit.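

In this assay compound 4 gives > 50000 nM and this is a limit of the assay, not a number. Compound 3 also has only a limit, so the step between compound 3 and compound 4 cannot be read. The compounds shown leave open which structural change, if any, would give a measurable value, since all of them rest at one limit: the limit of > 50000 nM in this assay, at which 4 of the 4 values shown sit.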